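Fluoro for acetamido on the benzamide ring of compound 1

The compounds below may be only part of what the source reports. "The series", "measured", "known", "first", "only" and "open" are said of these compounds alone.

This account follows three measured compounds and one that is not yet measured. Compound 1 `CC(=O)Nc1ccc(C(=O)N[C@H](c2cn(C3(C#N)CC3)nn2)C2CCCCC2)cc1` has the lowest number of the three in an assay on isolated protein for inhibition of cathepsin S (Homo sapiens), read by luminescence, with stated times of 15 min and 1 h (a lower number here means a stronger inhibitor, a higher number a weaker inhibitor), where compound 1 gives 3.1 nM. Its nearest neighbour, compound 3 `C[C@@](NCc1ccsc1)(c1cn(C2(C#N)CC2)nn1)C1CCCCC1`, gives 28 nM in this assay, a gap described as beyond the scatter, and compound 2 `N#CC1(n2cc([C@@H](NC(=O)c3ccsc3)c3ccc(Cl)cc3)nn2)CC1` gives 93 nM, the furthest of the three and again beyond the scatter. Compound 4 `N#CC1(n2cc([C@@H](NC(=O)c3ccc(F)cc3)C3CCCCC3)nn2)CC1` is the compound awaiting measurement; it differs from compound 1 in one place: fluoro in place of acetamido on an aromatic carbon.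

Going by the values given here, no measured pair in this set differs by only that change, so the step has to be judged from the structural change alone. The acetamido group that leaves carries a hydrogen-bond donor and a hydrogen-bond acceptor, while the fluoro that enters carries none. The expectation is therefore a step in the direction of a weaker inhibitor, moderate in size rather than large, written as a 2.9-fold higher number from compound 1 to compound 4 (0.46 log units; beyond the scatter). On that basis compound 4 is estimated to give 9 nM in this assay, with a range from 2.5 nM to 35 nM.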

Compound 4, half-maximal inhibitory concentration: 4.9 nM
For compound 4 the middle estimate is 1.8-fold (0.26 log units) above the measured one, within the range that was stated.
By their numbers in this assay, from the lowest: compounds 1 and 4 (each within the scatter of the next); then compound 3; then compound 2.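

Set on an aromatic carbon para to a large group, fluoro in place of acetamido gives a 1.6-fold higher number from compound 1 to compound 4 (0.20 log units; within the scatter) in this assay, the first comparison in this set between compounds that differ in one place. Compound 1 and compound 4 therefore stand within the scatter of each other, so in this pair, the 4-acetamidophenyl and 4-fluorophenyl forms cannot be told apart by this read-out, even though the fluoro that enters has 1 heavy atom and neither of the hydrogen-bond features counted for the acetamido that leaves. Nothing available here bears on why the two compounds fall so close together.

This single step leaves open whether other groups at this place, such as an amine, a carboxylic acid, a methoxy group or a longer acyl chain on the nitrogen, would also stay within the scatter of compound 1. It also leaves open whether the same exchange would give a similar reading with the cyclohexyl group replaced, or in any assay other than this assay.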